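Taking the Nitro Group off Compound 2

The compounds below may be only part of what the source reports. "The series", "measured", "known", "first", "only" and "open" are said of these compounds alone.

In a functional assay on U-251 cells (Homo sapiens) for inhibition, read by sulforhodamine B assay, with a stated time of 72 h (a lower number here means that less compound is needed, a higher number that more compound is needed for the effect), compound 1 `O=C(/C=C/c1ccc([N+](=O)[O-])o1)c1ccc(Br)cc1` gives 21400 nM and compound 2 `O=C(/C=C/c1ccc([N+](=O)[O-])o1)c1ccc(C2CCCCC2)cc1` gives 4400 nM, the lower of the two numbers. Compound 3 `O=C(/C=C/c1ccco1)c1ccc(C2CCCCC2)cc1` has hydrogen in place of nitro on an aromatic carbon. Within the data shown here, the only measured step is modest, a 4.9-fold lower number from compound 1 to compound 2 (0.69 log units; beyond the scatter), with cyclohexyl in place of bromo. It leaves the nitro untouched, so it is only a loose guide to size. A step of similar size towards a higher number is expected in this assay, though no measurement tests this change directly. The expected change is a 4.5-fold higher number from compound 2 to compound 3 (0.66 log units; beyond the scatter). For compound 3 the estimate is 20000 nM, with an expected range of 6000 nM to 70000 nM.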

Compound 3, half-maximal effective concentration: 26400 nM
Estimate against measurement, compound 3: 1.3-fold (0.12 log units) below, within the range that was stated.
By their numbers in this assay, from the lowest: compound 2; then compounds 1 and 3 (each within the scatter of the next).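

In this assay, hydrogen in place of nitro next to the ring oxygen gives a 6.0-fold higher number from compound 2 to compound 3 (0.78 log units; beyond the scatter) with the cyclohexyl group unchanged, so this position clearly affects the number. The earlier step left the nitro in place and could not show this. No measurement available here offers an explanation for this step. The compounds shown leave open what an amine or a carboxylic acid at this position would give, and whether removing nitro has a similar effect when bromo replaces cyclohexyl.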